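A few compounds are considered here, and "the series" means these few. Any claim that something is new, unique, unknown or untested is made for them only; others in the source may bear on it.

The compounds here share one core, and a functional assay on A549 cells (Homo sapiens) for inhibition, read by sulforhodamine B assay, with a stated time of 72 h (a higher number here means a weaker inhibitor of growth, a lower number a stronger inhibitor of growth), gives readings for three of them. Compound 1 (`CNC(=O)/C=C/c1ccncc1-c1ccc2ccccc2c1`) gives 6620 nM. Compound 3 (`CCOC(=O)/C=C/c1ccncc1-c1ccc2ccccc2c1`) gives 5380 nM, and a 1.2-fold lower number from compound 1 to compound 3 (0.09 log units; within the scatter) shows that a swap on a carbonyl carbon changed nothing beyond the scatter. Compound 2 (`NNC(=O)CCc1ccncc1-c1ccc2ccccc2c1`) gives > 10000 nM, which is a limit of the assay and not a number. Its true place is therefore unknown, and an at least 1.5-fold higher number from compound 1 to compound 2 (0.17 log units; that floor lies within the scatter) and an at least 1.8-fold lower number from compound 2 to compound 3 (0.26 log units; that floor lies within the scatter) give only floors.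

Compound 4 (`O=C(CCc1ccncc1-c1ccc2ccccc2c1)N1CCOCC1`) differs from compound 2 on a carbonyl carbon whose other neighbour is a saturated chain carbon: morpholin-4-yl in place of aminoamino on a carbonyl carbon. In short, morpholin-4-yl stands in place of aminoamino. The closest guide is the step from compound 1 to compound 3, also a swap on a carbonyl carbon, and its size was within the scatter. No large change is therefore expected, so a reading near the limit seems likely. The estimated step is an at least 1.1-fold lower number from compound 2 to compound 4 (0.04 log units; that floor lies within the scatter). For compound 4 the estimate is 9000 nM, with an expected range from 4000 nM to 20000 nM.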

Compound 4, concentration for 50% growth inhibition: > 10000 nM
Compound 4: only a limit was reported (the forecaster's own chance of this, stated with the estimate: 45%); middle value at least 1.1-fold (0.04 log units) from the limit.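

Compound 4 gives > 10000 nM, a limit of the assay and not a number. Within the data shown here, compound 2 stands at the same limit, so no step between compound 2 and compound 4 can be read: the limit of > 10000 nM in this assay, at which 2 of the 4 values shown sit. The compounds shown leave open whether morpholin-4-yl and aminoamino on this carbonyl carbon differ at all in this assay.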